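A few compounds are considered here, and "the series" means these few. Any claim that something is new, unique, unknown or untested is made for them only; others in the source may bear on it.

Measured compounds:
Compound 1, `COc1cc(-c2nnc(SCC(=O)c3ccc(C(F)(F)F)cc3)n2N)cc(OC)c1OC`, gives only a limit, > 100000 nM, in a functional assay on PC-3 cells (Homo sapiens) for antiproliferative activity, read by MTT assay, with a stated time of 48 h; on this read-out lower numbers stand for stronger inhibition and higher numbers for weaker inhibition.
Compound 2, `COc1ccc(C(=O)CSc2nnc(-c3cc(OC)c(OC)c(OC)c3)n2N)cc1`, gives 97900 nM in this assay.

Among the compounds with values here, compound 2 thus stands as the single numerical value in this assay; the other result is a limit. Within the data shown here, the one measured step, an at least 1.0-fold lower number from compound 1 to compound 2 (0.00 log units; that floor lies within the scatter), concerns a methoxy in place of a trifluoromethyl on an aromatic carbon, and compound 1 sits at the limit of > 100000 nM in this assay, at which 1 of the 2 values shown sits.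

Compound 3, `COc1cccc(NC(=O)CSc2nnc(-c3cc(OC)c(OC)c(OC)c3)n2N)c1`, differs from compound 2 by (3-methoxyphenyl)amino in place of 4-methoxyphenyl on a carbonyl carbon. Among the measured compounds shown here, no measured step touches this change, so nothing among the measured compounds points to a shift beyond the scatter in this assay. Compound 3 is therefore expected to fall near compound 2, at 100000 nM, within 40000 nM to 250000 nM. That estimate means an expected step of a 1.0-fold higher number from compound 2 to compound 3 (0.01 log units; within the scatter), with a fair chance that only a limit is reported.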

Compound 3, half-maximal inhibitory concentration: > 100000 nM
Compound 3 ended at the assay's limit (the forecaster's own chance of this, stated with the estimate: 50%); the middle value sits exactly at the limit.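

Compound 3 shows that a nitrogen-linked aromatic group on this carbonyl carbon, (3-methoxyphenyl)amino, does not move the result clear of the top of the range, with an at least 1.0-fold higher number from compound 2 to compound 3 (0.00 log units; that floor lies within the scatter). Compound 3 gives only a limit in this assay, and the step from compound 1 to compound 3 cannot be read because both results are limits. With this change, a second group on this carbonyl carbon reaches that limit: the limit of > 100000 nM in this assay, at which 2 of the 3 values shown sit.

The change alters the link and the methoxy placement together, so the compounds shown cannot separate the two, and (4-methoxyphenyl)amino would bear on that question. On these data alone, it also remains open whether a morpholine or a carboxylic acid on this carbonyl carbon would give a clearly lower number.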